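This account rests on a few compounds, and the source may have more. Where it says the series, first, only, none or still open, it means among the compounds named here.

Three compounds share one core and differ only in the group carried by the nitrogen on the aromatic ring: compound 1 `O=C1CCC(N2C(=O)c3ccc(Nc4ccccn4)cc3C2=O)C(=O)N1`, compound 2 `COc1ccc(Nc2ccc3c(c2)C(=O)N(C2CCC(=O)NC2=O)C3=O)cc1` and compound 3 `CCc1ccc(Nc2ccc3c(c2)C(=O)N(C2CCC(=O)NC2=O)C3=O)cc1`. In an assay on FRT-Jurkat cells for inhibition of nuclear factor NF-kappa-B complex (Homo sapiens), read by flow cytometry, with a stated time of 24 h, tested at 10 uM (a higher number here means more inhibition at the concentration tested (going by the name of the read-out), a lower number less inhibition), compound 1 gives 9%, compound 2 gives 29% and compound 3 gives 5%. Compound 3 thus holds the lowest of the three numbers, yet its gap to compound 1 is small, as a number 4 percentage points lower from compound 1 to compound 3 (within the scatter) shows, while the gap to compound 2, a number 24 percentage points lower from compound 2 to compound 3 (beyond the scatter), is larger. The other measured step, a number 20 percentage points higher from compound 1 to compound 2 (beyond the scatter), is of a similar modest size.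

Compound 4 `CC(C)c1ccc(Nc2ccc3c(c2)C(=O)N(C2CCC(=O)NC2=O)C3=O)cc1` is the next member. The change from compound 3 is methyl in place of hydrogen on a saturated chain carbon bound to an aromatic carbon and a saturated chain carbon. For the measured compounds named here, no measured step shows a methyl in place of hydrogen on a saturated chain carbon; the known steps either exchange the whole group on the nitrogen or put ethyl in place of methoxy on the aromatic carbon. The closest analogy, the modest drop in this assay from compound 2 to compound 3, does not carry over directly. The expectation is therefore a step no larger than the scatter, written as a number 3 percentage points higher from compound 3 to compound 4 (within the scatter). Compound 4 is expected to give about 8% in this assay, with a range from 0% to 25%.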

Compound 4, a percentage reported as inhibition, at one concentration (the size of the read-out at that concentration, not a potency): 11%
Estimate against measurement, compound 4: 3 percentage points below; measured number inside the range.
By their numbers in this assay, from the lowest: compounds 3, 1 and 4 (each within the scatter of the next); then compound 2.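

Methyl in place of hydrogen on a saturated chain carbon bound to an aromatic carbon and a saturated chain carbon, which turns ethyl into isopropyl, gives in this assay a number 6 percentage points higher from compound 3 to compound 4 (within the scatter) and is the first change of this kind in the series, a lengthening of the group by branching that leaves the read-out within the scatter. The methoxy group keeps its separate place against the larger alkyl group as well, with a number 18 percentage points lower from compound 2 to compound 4 (beyond the scatter) as the step, while the 4-isopropylphenyl group cannot be told apart from pyridin-2-yl on the nitrogen, with a number 2 percentage points higher from compound 1 to compound 4 (within the scatter) as the step, so compound 2 alone stands apart among these four compounds. Nothing shown here bears on the reason for these numbers.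

The compounds shown leave open whether the methoxy group's separate place extends to an ethoxy group, a hydroxyl group or an amine in place of the isopropyl group. They also leave open how a longer chain or a carboxylic acid at that place would read in this assay, and whether the flat result for ethyl and isopropyl holds beyond these two groups.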